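The source may hold more compounds than are shown below. What is called first, only, known or untested is meant among the compounds shown, and "the series" means these compounds.

Working notes on the series. Compound 1 `COc1cc(-c2nnc3n2NC(c2cccs2)C(C(=O)c2ccccc2)S3)cc(OC)c1OC` gives 86300 nM in a functional assay on PC-3 cells (Homo sapiens) for cytotoxicity, read by MTT assay, with a stated time of 48 h; on this read-out lower numbers stand for stronger inhibition and higher numbers for weaker inhibition. It sits at the upper end of the three numbers, though no gap to the others reaches beyond the scatter: compound 2 `COc1cc(-c2nnc3n2NC(c2ccco2)C(C(=O)c2ccccc2)S3)cc(OC)c1OC` gives 64300 nM, compound 3 `COc1cc(-c2nnc3n2NC(c2ccco2)C(C(=O)c2ccc(-c4ccccc4)cc2)S3)cc(OC)c1OC` gives 45900 nM, and the steps of a 1.3-fold lower number from compound 1 to compound 2 (0.13 log units; within the scatter) and a 1.4-fold lower number from compound 2 to compound 3 (0.15 log units; within the scatter) are both within the scatter. Compound 4 `COc1cc(-c2nnc3n2NC(c2cccs2)C(C(=O)c2ccc(Cl)cc2)S3)cc(OC)c1OC` differs from compound 1 by chloro in place of hydrogen on an aromatic carbon, on an aromatic carbon of a six-membered aromatic ring of carbon only, para to a large group; benzoyl becomes (4-chlorophenyl)carbonyl. Among the compounds with values here, the one step bearing on it, the change on the same aromatic ring from compound 2 to compound 3, was within the scatter, so no step beyond the scatter is expected in this assay. For compound 4 the expected value is 75000 nM (range 35000 nM to 160000 nM), a step of a 1.2-fold lower number from compound 1 to compound 4 (0.06 log units; within the scatter).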

Compound 4, half-maximal inhibitory concentration: 32500 nM
Beside the measured number, compound 4's estimate is 2.3-fold (0.36 log units) above it, and the stated range ends above it.
By their numbers in this assay, from the lowest: compounds 4, 3, 2 and 1 (each within the scatter of the next, the first and the last beyond it).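

In this assay, chloro in place of hydrogen on this aromatic carbon gives a 2.7-fold lower number from compound 1 to compound 4 (0.42 log units; beyond the scatter), a modest step and the first in the series to pass the scatter. The earlier change on the same ring, a 1.4-fold lower number from compound 2 to compound 3 (0.15 log units; within the scatter), stayed within it, so this position is now seen to respond, at least with thiophen-2-yl on the saturated ring carbon. Nothing available accounts for the step.

On these data alone, whether fluoro, methoxy or an amine at this position would match chloro remains open. So does whether chloro gives a similar step on furan-2-yl compound 2.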